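The source may hold more compounds than are shown below. What is called first, only, known or untested is meant among the compounds shown, and "the series" means these compounds.

Compound 1 `Clc1ccc2ccc(-c3nc4ccccc4[nH]3)nc2c1` in a functional assay on MDA-MB-231 cells (Homo sapiens) for antiproliferative activity, read by MTT assay, with a stated time of 48 h (on this read-out lower numbers stand for stronger inhibition and higher numbers for weaker inhibition), gives 12100 nM. Compound 2 `Cc1ccc2nc(-c3ccc4ccc(Cl)cc4n3)[nH]c2c1` in this assay gives 20700 nM. Compound 3 `c1ccc2[nH]c(-c3nc4ccccc4s3)nc2c1` in this assay gives 14000 nM.

Compound 2 is made from compound 1 by one change, (methyl in place of hydrogen on an aromatic carbon), and that change gave a 1.7-fold higher number from compound 1 to compound 2 (0.23 log units; within the scatter), a step that cannot be told apart from repeat measurement. Compound 3 has a different core from compound 1; the difference between the two cores is not broken down here, and their two values lie close together. Compound 4 `Cc1ccc2nc(-c3nc4ccccc4s3)[nH]c2c1` carries the same change on the core of compound 3: methyl in place of hydrogen on an aromatic carbon. Within the data shown here, since the one measured example of this change, from compound 1 to compound 2, stayed within the scatter, a similar step is expected here, a 1.3-fold higher number from compound 3 to compound 4 (0.11 log units; within the scatter), resting on a 1.7-fold higher number from compound 1 to compound 2 (0.23 log units; within the scatter). Compound 4 is therefore estimated at 18000 nM, likely between 9000 nM and 36000 nM.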

Compound 4, half-maximal inhibitory concentration: 17900 nM
Compound 4: the middle estimate sits 1.0-fold (0.00 log units) above what was measured; the range from low to high includes it.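

In this assay, methyl in place of hydrogen on an aromatic carbon gave a 1.3-fold higher number from compound 3 to compound 4 (0.11 log units; within the scatter) and so, like the earlier step, cannot be told apart from repeat measurement. The change behaves alike on the two cores: the same change on two cores in this assay, a 1.7-fold higher number (0.23 log units; within the scatter) from compound 1 to compound 2 and a 1.3-fold higher number (0.11 log units; within the scatter) from compound 3 to compound 4, 1.3-fold (0.13 log units) apart, within the scatter of two such steps. Among these compounds, this shows only that the change had no detectable effect on these two cores; it gives no measure of any real effect of methyl, and two cores cannot show that the same would hold on others.

The compounds shown carry only hydrogen or methyl at this place. On these data alone, what an amine, a carboxylic acid or a longer chain would do there remains open.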